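Changing the aryl group on the sulfonyl sulfur: compound 4

A few compounds are considered here, and "the series" means these few. Any claim that something is new, unique, unknown or untested is made for them only; others in the source may bear on it.

Three compounds sharing one core have been tested in an assay on HEK293 cells for displacement of a labelled ligand from 5-hydroxytryptamine receptor 6 (Homo sapiens), with a stated time of 60 min, tested at 0.01 uM, in the presence of a further agent that is not named here; on this read-out higher numbers stand for a stronger effect at the one concentration tested and lower numbers for a weaker effect:

compound 1, `COc1cc(N)c(Cl)cc1C(=O)CCC1CCN(CCNS(=O)(=O)c2cc(Br)ccc2Br)CC1`, gives 16%
compound 2, `COc1ccc(S(=O)(=O)NCCN2CCC(CCC(=O)c3cc(Cl)c(N)cc3OC)CC2)cc1Cl`, gives 20%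
compound 3, `COc1cc(N)c(Cl)cc1C(=O)CCC1CCN(CCNS(=O)(=O)c2ccc(NC(C)=O)cc2)CC1`, gives 7%

Compound 3 stands lowest of the three. One of the steps ending at it is small (a number 9 percentage points lower from compound 1 to compound 3 (within the scatter)), while the other is larger (a number 13 percentage points lower from compound 2 to compound 3 (beyond the scatter)). Compound 1 and compound 2 sit close together (a number 4 percentage points higher from compound 1 to compound 2 (within the scatter)).

Compound 4, `COc1cc(N)c(Cl)cc1C(=O)CCC1CCN(CCNS(=O)(=O)c2cc(Br)c(N)c(Br)c2)CC1`, has not yet been measured. It differs from compound 3 in one place: 4-amino-3,5-dibromophenyl in place of 4-acetamidophenyl on a sulfonyl sulfur.

Going by the values given here, the steps that bear on this change are those in which the 4-acetamidophenyl group of compound 3 is exchanged for another aryl on the sulfonyl sulfur. Going from compound 1 to compound 3 gave a number 9 percentage points lower from compound 1 to compound 3 (within the scatter), and from compound 2 to compound 3 gave a number 13 percentage points lower from compound 2 to compound 3 (beyond the scatter). Read in reverse, moving away from 4-acetamidophenyl toward a bromine-bearing aryl went with a small rise, so a modest upward step is expected for compound 4, estimated at a number 8 percentage points higher from compound 3 to compound 4 (within the scatter).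

Compound 4 is therefore estimated at 15%, within a range from 3% to 30%.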

Compound 4, a percentage reported as inhibition, at one concentration (the size of the read-out at that concentration, not a potency): 52%
Estimate against measurement, compound 4: 37 percentage points below; measured number above the stated range.
By their numbers in this assay, from the lowest: compounds 3, 1 and 2 (each within the scatter of the next, the first and the last beyond it); then compound 4.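

In this assay, the aryl group on the sulfonyl sulfur can shift the number far more than the first three compounds suggested: 4-amino-3,5-dibromophenyl in place of 4-acetamidophenyl gives a number 45 percentage points higher from compound 3 to compound 4 (beyond the scatter), and the new group also stands well clear of the other two aryl groups (a number 32 percentage points higher from compound 2 to compound 4 (beyond the scatter); a number 36 percentage points higher from compound 1 to compound 4 (beyond the scatter)). Bromine on this aryl group is not enough on its own, since the 2,5-dibromophenyl group of compound 1 also carries two bromine atoms, yet compound 1 gives 16% and remains within the scatter of compound 3. No measurement at hand gives a reason for the rise.

Going by these compounds, what stays open is whether the gain depends on the amino group, on the two bromine atoms, or on both together: a plain 4-aminophenyl group and a 3,5-dibromophenyl group without the amine would pull these apart. On these data alone, each number also comes from a single concentration, so it is still unknown how potent compound 4 is.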